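The source may report more compounds than this note shows. Statements on the series, on what has been measured and on what is new or still open speak of the compounds shown alone.

In an ADME assay on HEK293 cells (Homo sapiens) for cytotoxicity, with a stated time of 72 h (a higher number here means that more compound is needed for the effect, a lower number that less compound is needed), compound 3 `COc1ccc(/C=C/[C@@](C)(/C=C/c2ccc(O)c(/C=C/C#N)c2)CCC=C(C)C)cc1` gives only a limit, > 36600 nM. Compound 1 `C=C[C@@](C)(/C=C/c1ccc(O)c(/C=C/C(=O)OCC)c1)CCC=C(C)C` also gives only a limit, > 36600 nM. Compound 2 `COc1ccc(/C=C/[C@@](C)(/C=C/c2ccc(O)c(C=O)c2)CCC=C(C)C)cc1` reads 2270 nM. For the measured compounds named here, the one measured step, an at least 16-fold higher number from compound 2 to compound 3 (1.20 log units; beyond the scatter), is large, but it replaces formyl with 2-cyanoethenyl, so it says little about a change within that chain. Compound 4 `CCOC(=O)/C=C/c1cc(/C=C/[C@](C)(/C=C/c2ccc(OC)cc2)CCC=C(C)C)ccc1O` carries ethoxycarbonyl in place of cyano on a double-bonded chain carbon bound to a double-bonded chain carbon. Compound 1 already holds the same 2-(ethoxycarbonyl)ethenyl and belongs to the limit of > 36600 nM in this assay, at which 2 of the 3 values shown sit, so no step beyond the scatter is expected in this assay. The expected step is an at least 1.2-fold lower number from compound 3 to compound 4 (0.08 log units; that floor lies within the scatter). For compound 4 the estimated value is 30000 nM, within 10000 nM to 60000 nM.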

Compound 4, half-maximal effective concentration: > 36600 nM
Compound 4 was reported as a limit (the forecaster's own chance of this, stated with the estimate: 60%); middle value at least 1.2-fold (0.08 log units) away from the limit.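

In this assay, a second replacement of formyl on an aromatic carbon, this time by 2-(ethoxycarbonyl)ethenyl, also gives a large step: an at least 16-fold higher number from compound 2 to compound 4 (1.20 log units; beyond the scatter). Compound 4 gives only a limit, and its steps from compound 3 and from compound 1 cannot be read. Among the compounds shown, only compound 2, with formyl, gives a number, while the others share one limit: the limit of > 36600 nM in this assay, at which 3 of the 4 values shown sit.

Going by these compounds, whether ethoxycarbonyl and cyano differ on the chain remains open. Also open, on these data alone, is whether a carboxylic acid on that chain, or an aminomethyl group on that aromatic carbon, would give a number.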